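Bromo in place of hydrogen on compound 3

A few compounds are considered here, and "the series" means these few. Any claim that something is new, unique, unknown or untested is made for them only; others in the source may bear on it.

Of the compounds shown here, three sharing one core have been measured in a functional assay on the whole organism for antagonist activity, with Mus musculus as the target; a higher number here means that more compound is needed for the effect, a lower number that less compound is needed. Compound 1 (`CCC(=O)N(c1ccc(OC)cc1)C1CCCC1N(C)C`) gives 20 mg/kg; 20 mg/kg (2 entries), and compound 2 (`CCC(=O)N(c1cccc(Br)c1)C1CCCC1N(C)C`) gives 0.1 mg/kg. Compound 3 (`CCC(=O)N(c1ccc(Br)cc1)C1CCCC1N(C)C`) gives 3 mg/kg, a number well beyond the usual scatter above that of compound 2, yet still below that of compound 1.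

Compound 4 (`CCC(=O)N(c1ccc(Br)c(Br)c1)C1CCCC1N(C)C`) is compound 3 with bromo in place of hydrogen on an aromatic carbon, ortho to a bromo group and meta to a large group: bromo in place of hydrogen on an aromatic carbon. It has not yet been tested in this assay. The expectation of a lower number rests on compound 2, which also carries a bromo group and gives 0.1 mg/kg. Going by the values given here, no compound with two bromo groups has been measured, so the expectation remains loose. The expected change is a moderate drop, estimated as a 6.0-fold lower number from compound 3 to compound 4 (0.78 log units; beyond the scatter). For compound 4 the estimate is 0.5 mg/kg, with an expected range from 0.1 mg/kg to 2.5 mg/kg.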

Compound 4, dose for half-maximal effect: 0.2 mg/kg
Beside the measured number, compound 4's estimate is 2.5-fold (0.40 log units) above it; the range from low to high includes it.
By their numbers in this assay, from the lowest: compounds 2 and 4 (each within the scatter of the next); then compound 3.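

In this assay, compound 4 shows that bromo on this aromatic carbon, ortho to a bromo group and meta to a large group, carries a large step even with a bromo group already in place (a 15-fold lower number from compound 3 to compound 4 (1.18 log units; beyond the scatter)). Compound 4 holds both of the bromo placements seen singly in compound 2 and compound 3, and its number falls in with that of compound 2 rather than that of compound 3 (a 2.0-fold higher number from compound 2 to compound 4 (0.30 log units; within the scatter)). Going by these compounds alone, two bromo groups on the ring are thus compatible with a low dose here, which no single-bromo compound could show.

The compounds shown leave open whether a chloro group, a methyl group or an amine on this same aromatic carbon would give a comparable step. No measurement offers an explanation for the size of this step.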